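The source may hold more compounds than are shown below. What is called first, only, known or untested is meant among the compounds shown, and "the series" means these compounds.

Measured so far in the series:
compound 3 `O=C(Nc1cccc([N+](=O)[O-])c1)N1CCN(S(=O)(=O)c2sccc2-c2ccccc2Oc2ccc(O)c(O)c2)CC1` gives 9800 nM
compound 2 `O=C(NCCNS(=O)(=O)c1ccc(-c2ccccc2O[C@H]2CC[C@H](O)CC2)s1)Nc1cc(Cl)cc(Cl)c1` gives 14100 nM
compound 1 `O=C(NCCNS(=O)(=O)c1cc(-c2ccccc2Oc2ccc(O)c(O)c2)cs1)Nc1cc(C(F)(F)F)cc(C(F)(F)F)c1` gives 3900 nM

All three numbers come from a functional assay on RS4-11 cells (Homo sapiens) for inhibition, read by CCK-8 assay, with a stated time of 48 h; on this read-out higher numbers stand for weaker inhibition and lower numbers for stronger inhibition. Compound 3 stands second highest of the three; compound 2 lies nearest, within the scatter of compound 3, while compound 1 lies furthest, with a lower number beyond the scatter.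

Compound 4 `O=[N+]([O-])c1ccc(NC(=S)N2CCN(S(=O)(=O)c3sccc3-c3ccccc3Oc3ccc(O)c(O)c3)CC2)cc1` has not been measured. It differs from compound 3 in one place: a group of 12 heavy atoms (7 carbon, 2 nitrogen, 2 oxygen, 1 sulfur; one six-membered aromatic ring of carbon only) in place of a group of 12 heavy atoms (7 carbon, 2 nitrogen, 3 oxygen; one six-membered aromatic ring of carbon only), on an amine nitrogen in a ring. Within the data shown here, no pair of measured compounds separated by this change exists, so the data give no size for it. The expectation in this assay is a step of no more than the scatter, with no clear direction. Compound 4 is therefore estimated at 9000 nM, with a range from 3000 nM to 27000 nM. The expected step of a 1.1-fold lower number from compound 3 to compound 4 (0.04 log units; within the scatter) is small.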

Compound 4, half-maximal inhibitory concentration: 9000 nM
Beside the measured number, compound 4's estimate shows no gap at the digits printed; the measured number falls inside the stated range.
By their numbers in this assay, from the lowest: compound 1; then compounds 4, 3 and 2 (each within the scatter of the next).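

In this assay, among these compounds, this is the first step read on the amine nitrogen in the ring: replacing (3-nitrophenyl)carbamoyl with a same-sized group that carries one sulfur and one oxygen fewer gives a 1.1-fold lower number from compound 3 to compound 4 (0.04 log units; within the scatter). This position therefore accepts this change without a separation in the read-out. No supporting measurement bears on why.

This single step cannot show which difference within the entering group matters, if any. On these data alone, whether an acetyl group or a plain benzyl group on this nitrogen would also leave the number unmoved remains open.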